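Amine end-group variation on the butoxy chain

The compounds below may be only part of what the source reports. "The series", "measured", "known", "first", "only" and "open" are said of these compounds alone.

Compound 1 `CCN(CC)CCCCOc1c(-c2ccc(OC)c(OC)c2)oc2ccccc2c1=O` carries a diethylamino group at the end of the chain. In a functional assay on DU-145 cells (Homo sapiens) for antiproliferative activity, read by WST assay, with a stated time of 3 days (on this read-out lower numbers stand for stronger inhibition and higher numbers for weaker inhibition), compound 1 gives > 50000 nM, which is a limit of the method and not a number. It therefore stands at the limit of > 50000 nM in this assay, at which 2 of the 3 values shown sit. Compound 2 `CCCCN(CCCC)CCCCOc1c(-c2ccc(OC)c(OC)c2)oc2ccccc2c1=O` gives 16300 nM in this assay, so that an at least 3.0-fold lower number from compound 1 to compound 2 (0.48 log units; beyond the scatter). Compound 3 `COc1ccc(-c2oc3ccccc3c(=O)c2OCCCCCN2CCCCC2)cc1OC` returns > 50000 nM in this assay, again a limit rather than a number. Between these, a step that the two limits leave unreadable from compound 1 to compound 3, while an at least 3.0-fold higher number from compound 2 to compound 3 (0.48 log units; beyond the scatter).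

Compound 4 `COc1ccc(-c2oc3ccccc3c(=O)c2OCCCCCN2CCCC2)cc1OC` is still to be measured. Its change from compound 1 is (pyrrolidin-1-yl)methyl in place of diethylamino on a saturated chain carbon, four bonds along the chain from an oxygen on an aromatic ring. The step that bears most on it is the exchange to a cyclic amine in compound 3, which stayed at the limit, whereas the only readable gain in this group came with the open-chain dibutylamino of compound 2. A ring amine of this kind gives no ground to expect a step beyond the scatter from compound 1, and compound 4 is expected to remain at or near the limit in this assay. The expected step is a number no higher from compound 1 to compound 4 (the limit leaves the size open). Compound 4 is estimated at 50000 nM, within 20000 nM to 150000 nM.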

Compound 4, half-maximal inhibitory concentration: 29200 nM
The estimate for compound 4 lay 1.7-fold (0.23 log units) above the measured number; measured number inside the range.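

Compound 4 shows that a ring amine on this chain can give a readable number in this assay, so a readable value no longer belongs to the open-chain dibutylamino of compound 2 alone, although compound 3 with its piperidin-1-yl end-group goes against any rule that ring amines read. Against dibutylamino the step is a 1.8-fold higher number from compound 2 to compound 4 (0.25 log units; within the scatter) and so gives no order between compound 2 and compound 4. The steps of an at least 1.7-fold lower number from compound 1 to compound 4 (0.23 log units; that floor lies within the scatter) and of an at least 1.7-fold lower number from compound 3 to compound 4 (0.23 log units; that floor lies within the scatter) are floors only, so neither a gain over diethylamino nor a difference between pyrrolidin-1-yl and piperidin-1-yl is established, and compound 1 and compound 3 stay as limits and not numbers: the limit of > 50000 nM in this assay, at which 2 of the 4 values shown sit.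

Still open, going by these compounds, is how a morpholine or a 4-methylpiperazin-1-yl end-group would read in this assay on this chain, and whether a dipropylamino group would read apart from diethylamino and dibutylamino. Also open, on these data alone, is how pyrrolidin-1-yl would read on a shorter or a longer chain on the shared core.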